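This account rests on a few compounds, and the source may have more. Where it says the series, first, only, none or still open, it means among the compounds named here.

Working notes on the series in a functional assay on U-87MG ATCC cells (Homo sapiens) for cytotoxicity, read by MTT assay, with a stated time of 24 h; on this read-out lower numbers stand for stronger inhibition and higher numbers for weaker inhibition. Three compounds have been run. Compound 1 `COc1ccccc1C(=O)Nc1cn(-c2ccccc2)nc1-c1ccccc1` gives 81000 nM. Compound 2 `O=C(CCCCCCCCCCS)Nc1cn(-c2ccccc2)nc1-c1ccccc1` gives in this assay 90000 nM. Compound 3 `Cn1cc(NC(=O)c2ccccc2)c(-c2ccccn2)n1` stands on a different core from the first two, with a methyl and a pyridyl group in place of the two phenyl groups. In this assay compound 3 returns only a limit of the measurement, > 150000 nM, and no number. From the compounds shown here alone, that puts compound 3 at the limit of > 150000 nM in this assay, at which 1 of the 3 values shown sits; where it sits below that limit is unknown.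

Compound 4 `COc1ccccc1C(=O)Nc1cn(C)nc1-c1ccccn1` is the next compound for this assay. It keeps the core of compound 3 and differs from it in one place: methoxy in place of hydrogen on an aromatic carbon. For the measured compounds named here, no measured pair carries this change on its own. Going by the values given here, compound 1 also bears a methoxy on its amide ring and gives 81000 nM, but its core is not that of compound 3, so the two values show only that a methoxy compound can sit in the weak range. Since compound 3 itself is a limit, no step size can be fixed; the expectation is a step of a number no higher from compound 3 to compound 4 (the limit leaves the size open), with compound 4 staying in the weak region rather than moving beyond the scatter. Compound 4 is estimated at 150000 nM, with a range of 60000 nM to 400000 nM, and a substantial chance that this assay again reports only a limit.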

Compound 4, half-maximal inhibitory concentration: 130000 nM
Compound 4: the middle estimate sits 1.2-fold (0.06 log units) above what was measured, and the stated range covers the measured number.
By their numbers in this assay, from the lowest: compounds 1, 2 and 4 (each within the scatter of the next). At a limit, above all of these: compound 3.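

Methoxy in place of hydrogen on an aromatic carbon, ortho to a large group, gives an at least 1.1-fold lower number from compound 3 to compound 4 (0.06 log units; that floor lies within the scatter) in this assay. Compound 3 is a limit and not a number, so only the floor of this step can be read and its true size stays unknown: the limit of > 150000 nM in this assay, at which 1 of the 4 values shown sits.

What is new is that the core of compound 3 now has a measured number, with compound 4 at 130000 nM, so a methoxy at this place yields a value that can serve as a reference for further changes on this core.

Left open is whether an amine or a carboxylic acid in place of the methoxy, at this same place on the amide ring, would move the number beyond the scatter from compound 4. Equally open, from the compounds shown here alone, is whether the same change from hydrogen to methoxy on the core of compound 1 gives a step of like size, and so whether the reading carries from one core to the other.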